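The source may report more compounds than this note shows. Statements on the series, on what has been measured and on what is new or still open speak of the compounds shown alone.

Measured in a functional assay on B16 cells (Mus musculus) for cytotoxicity, read by MTT assay, with a stated time of 48 h; a lower number here means a stronger inhibitor, a higher number a weaker inhibitor:
compound 1 `C#Cc1ccc(NC(=O)c2cn(CC(=O)OCC)nn2)cc1`: > 100000 nM
compound 2 `O=C(Nc1ccccc1)c1cn(Cc2ccccc2)nn1`: 93000 nM

Going by the values given here, compound 2 gives 93000 nM, the only true number among the measurements so far. For compound 1 the reading of > 100000 nM is a limit of the assay and not a number.

The next compound to be tested is compound 3 `CCOC(=O)Cn1cc(C(=O)Nc2ccccc2)nn1`, which differs from compound 2 in one place. The change is ethoxycarbonyl in place of phenyl on a saturated chain carbon bound to an aromatic nitrogen, so that benzyl gives way to (ethoxycarbonyl)methyl.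

Among the compounds with values here, no step between measured compounds is available to show what such a change does in this assay. Only a small step is expected, toward weaker inhibition if there is any, and it may stay within the usual scatter. The reason for expecting so little is that compound 2, at 93000 nM, already stands high on this scale, leaving little room. The assay may well report only a limit for compound 3.

The estimated change is a 1.1-fold higher number from compound 2 to compound 3 (0.03 log units; within the scatter). For compound 3 the expected value is 100000 nM, with an estimated range of 40000 nM to 250000 nM.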

Compound 3, half-maximal inhibitory concentration: > 100000 nM
Compound 3: a limit, no number; the forecaster's own chance of this, stated with the estimate: 60%; the middle value lies on the limit itself.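

In this assay compound 3 gives > 100000 nM, a limit of the assay and not a number. Putting ethoxycarbonyl in place of phenyl on a saturated chain carbon bound to an aromatic nitrogen gives an at least 1.0-fold higher number from compound 2 to compound 3 (0.03 log units; that floor lies within the scatter), so the change from benzyl to (ethoxycarbonyl)methyl shows no gain in inhibition at this position, while the size of any loss stays hidden. The step between compound 1 and compound 3 cannot be read, and the change can be given only as a floor because of where the readings sit: the limit of > 100000 nM in this assay, at which 2 of the 3 values shown sit.

Going by these compounds, it remains open whether a carboxylic acid in place of the ethoxycarbonyl, or a longer chain ending in an amine, would give a true number rather than a limit in this assay. Also open, on these data alone, is how far compound 3 lies past its limit, and so whether the change from benzyl costs little or much.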